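Phenyl in place of isobutyl in compound 4

This account rests on a few compounds, and the source may have more. Where it says the series, first, only, none or still open, it means among the compounds named here.

Measured so far in a physicochemical assay for solubility, in phosphate buffer, at pH 6.5; a lower number here means a less soluble compound, a higher number a more soluble compound
compound 1 `C=C[C@@H]1C[C@]1(NC(=O)[C@@H]1C[C@@H](Oc2nccc3cc(OC)ccc23)CN1C(=O)[C@@H](NC(=O)NC(C)(C)C)C(C)(C)C)C(=O)NS(=O)(=O)C1CC1` gives 13 ug/mL
compound 2 `C=C[C@@H]1C[C@]1(NC(=O)[C@@H]1C[C@@H](Oc2nccc3cc(OC)ccc23)CN1C(=O)[C@@H](NC(=O)N[C@H](COC)C(C)C)C(C)(C)C)C(=O)NS(=O)(=O)C1CC1` gives 570 ug/mL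
compound 3 `C=C[C@@H]1C[C@]1(NC(=O)[C@@H]1C[C@@H](Oc2nccc3cc(OC)ccc23)CN1C(=O)[C@@H](NC(=O)N[C@H](COC)CC(C)C)C(C)(C)C)C(=O)NS(=O)(=O)C1CC1` gives 225 ug/mL

Compound 3 at 225 ug/mL holds the middle of the three numbers, under compound 2 and over compound 1. Compound 4 `C=C[C@@H]1C[C@]1(NC(=O)[C@@H]1C[C@@H](Oc2nccc3cc(OC)ccc23)CN1C(=O)[C@@H](NC(=O)N[C@H](COC)c1ccccc1)C(C)(C)C)C(=O)NS(=O)(=O)C1CC1` carries phenyl in place of isobutyl on a saturated chain carbon bound to an amide-type nitrogen and a saturated chain carbon. The nearest evidence is a modest step at that same place (a 2.5-fold lower number from compound 2 to compound 3 (0.40 log units; beyond the scatter)). The large steps (a 44-fold higher number from compound 1 to compound 2 (1.64 log units; beyond the scatter) and a 17-fold higher number from compound 1 to compound 3 (1.24 log units; beyond the scatter)) replace tert-butyl and bear on it less. No phenyl has been measured at this place, so the direction remains uncertain. A modest step to a lower number is expected (a 1.7-fold lower number from compound 3 to compound 4 (0.24 log units; within the scatter)). Compound 4 is estimated at 130 ug/mL (range 40 ug/mL to 400 ug/mL).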

Compound 4, solubility: 259 ug/mL
Beside the measured number, compound 4's estimate is 2.0-fold (0.30 log units) below it; the range from low to high includes it.
By their numbers in this assay, from the lowest: compound 1; then compounds 3 and 4 (each within the scatter of the next); then compound 2.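

In this assay, phenyl on a saturated chain carbon bound to an amide-type nitrogen and a saturated chain carbon reads the same as isobutyl within the scatter (a 1.2-fold higher number from compound 3 to compound 4 (0.06 log units; within the scatter)), so a six-membered aromatic ring is tolerated here as well as a branched chain. Isopropyl still stands apart from phenyl (a 2.2-fold lower number from compound 2 to compound 4 (0.34 log units; beyond the scatter)), while 2-methoxy-1-phenylethyl keeps the large rise over tert-butyl (a 20-fold higher number from compound 1 to compound 4 (1.30 log units; beyond the scatter)) that compound 2 and compound 3 showed. Nothing given here explains these numbers. Going by these compounds, what a pyridine ring or a chain ending in an amine would give at this place remains open.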